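A few compounds are considered here, and "the series" means these few. Any claim that something is new, unique, unknown or untested is made for them only; others in the source may bear on it.

Compound 1 `CC[C@@H]1C(=O)N(C)c2cnc(-n3ccc4cc(F)ccc43)nc2N1C1CCCC1` carries a fluoro on the fused bicyclic part attached to the shared core. In a functional assay on A549 cells (Homo sapiens) for antiproliferative activity, read by CCK-8 assay, with a stated time of 72 h (on this read-out higher numbers stand for weaker inhibition of growth and lower numbers for stronger inhibition of growth), compound 1 is reported as "not active" (no number reported), so no single number places it on the scale. Two other members of the set belong to a different substitution pattern on the core: compound 2 `CCC1C(=O)N(C)c2cnc(Nc3ccc(S(=O)(=O)NCCCO)cc3)nc2N1c1ccn(C)n1` gives 48900 nM in this assay, and compound 3 `CCC1C(=O)N(C)c2cnc(Nc3ccc(S(N)(=O)=O)cc3)nc2N1c1ccn(C)n1` is reported as "not active" (no number reported) in this assay. Among the measured compounds shown here, no step between measured pairs differing in one place is available, so the set offers no calibrated change; it shows only that one member reaches a weak measurable value and two do not.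

Compound 4 `CC[C@@H]1C(=O)N(C)c2cnc(-n3ccc4cc(C(=O)NC)ccc43)nc2N1C1CCCC1` differs from compound 1 by methylcarbamoyl in place of fluoro on an aromatic carbon. With compound 1 giving "not active" (no number reported) in this assay, and no measured step to anchor the size of such a change, the expectation is for a movement of modest size at most, if any, toward stronger inhibition; the series gives no reason to expect a large shift. Compound 4 is estimated at 50000 nM in this assay, with a range from 10000 nM to 250000 nM, and a real chance that only an inactive result is again reported.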

Compound 4, concentration for 50% growth inhibition: 2200 nM
Beside the measured number, compound 4's estimate is 23-fold (1.36 log units) above it; measured number below the stated range.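

No step can be read between compound 1 and compound 4: in this assay, compound 1 stands as "not active" (no number reported) and compound 4 as 2200 nM. Going by these compounds, the size of the change from fluoro to methylcarbamoyl on this aromatic carbon stays open. No supporting data bear on this result.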